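Chain homologation on the catechol and diacetate cores

This account rests on a few compounds, and the source may have more. Where it says the series, first, only, none or still open, it means among the compounds named here.

Measured so far in a functional assay on BV-2 cells (Mus musculus), read by Griess assay, with stated times of 3 h and 24 h; on this read-out higher numbers stand for weaker inhibition and lower numbers for stronger inhibition:
- compound 1 `O=C(/C=C/c1ccc(O)c(O)c1)CCCc1ccccc1` gives 6400 nM
- compound 2 `O=C(/C=C/c1ccc(O)c(O)c1)CCCCc1ccccc1` gives 5900 nM
- compound 3 `CC(=O)Oc1ccc(/C=C/C(=O)CCCc2ccccc2)cc1OC(C)=O` gives 5300 nM

The step of a 1.1-fold lower number from compound 1 to compound 2 (0.04 log units; within the scatter) is the change (benzyl in place of phenyl on a saturated chain carbon, three bonds along the chain from a carbonyl carbon). The difference between the core of compound 1 and the core of compound 3 is not broken down here. Compound 4 `CC(=O)Oc1ccc(/C=C/C(=O)CCCCc2ccccc2)cc1OC(C)=O` has not yet been measured in this assay; it carries the same change, (benzyl in place of phenyl on a saturated chain carbon, three bonds along the chain from a carbonyl carbon), on the core of compound 3, at the same place as in compound 2.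

Since the change from compound 1 to compound 2 gave a step within the scatter, the expected step for compound 4 is also small, a 1.1-fold lower number from compound 3 to compound 4 (0.03 log units; within the scatter), resting on compound 3 with its 5300 nM as the anchor. Compound 4 is therefore estimated at 5000 nM, with the range 2500 nM to 10000 nM.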

Compound 4, half-maximal inhibitory concentration: 4200 nM
The estimate for compound 4 lay 1.2-fold (0.08 log units) above the measured number, and the stated range covers the measured number.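

In this assay, benzyl in place of phenyl on a saturated chain carbon, three bonds along the chain from a carbonyl carbon, gives a 1.3-fold lower number from compound 3 to compound 4 (0.10 log units; within the scatter). Set beside the same change on the core of compound 1, the two steps do not differ: the same change on two cores in this assay, a 1.1-fold lower number (0.04 log units; within the scatter) from compound 1 to compound 2 and a 1.3-fold lower number (0.10 log units; within the scatter) from compound 3 to compound 4, 1.2-fold (0.07 log units) apart, within the scatter of two such steps This shows that the change behaves alike on these two cores, with a step too small to read on either; it does not show a real gain from the added carbon, nor that the agreement would hold on any other core.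

Open, on these data alone, is whether a longer chain would give a step beyond the scatter on either core. Also open, as far as these compounds go, is what an amine or a carboxylic acid in place of the benzyl would give.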